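Methoxy to hydroxy, starting from compound 2

This account rests on a few compounds, and the source may have more. Where it says the series, first, only, none or still open, it means among the compounds named here.

In a functional assay on K-562R cells (Homo sapiens) for cytotoxicity, read by MTT assay, with a stated time of 48 h (on this read-out lower numbers stand for stronger inhibition and higher numbers for weaker inhibition), compound 1 (`COc1ccc(-c2cn(C(=O)Nc3cc(OC)c(OC)c(OC)c3)c(=O)n2-c2cc(OC)c(OC)c(OC)c2)cc1`) gives 3500 nM. Compound 2 (`COc1ccc(-c2cn(C(=O)Nc3cc(OC)c(OC)c(OC)c3)c(=O)n2-c2cc(OC)c(OC)c(OC)c2)cc1OC`) gives > 50000 nM, which is a limit of the assay and not a number. Going by the values given here, the one measured step bearing on the next change is an at least 14-fold higher number from compound 1 to compound 2 (1.15 log units; beyond the scatter), for methoxy in place of hydrogen on an aromatic carbon. Compound 3 (`COc1ccc(-c2cn(C(=O)Nc3cc(OC)c(OC)c(OC)c3)c(=O)n2-c2cc(OC)c(OC)c(OC)c2)cc1O`) has hydrogen in place of methyl on an oxygen on an aromatic ring, so 3,4-dimethoxyphenyl becomes 3-hydroxy-4-methoxyphenyl. The expected change, large and towards a lower number, is an at least 6.2-fold lower number from compound 2 to compound 3 (0.79 log units; beyond the scatter). The estimate for compound 3 is 8000 nM, with an expected range of 1500 nM to 50000 nM.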

Compound 3, half-maximal inhibitory concentration: > 50000 nM
Compound 3 gave a limit, no number; the forecaster's own chance of this, stated with the estimate: 20%; middle value at least 6.2-fold (0.79 log units) from the limit.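

Removing the methyl does not recover the number of compound 1, so hydroxy on this aromatic carbon is no better tolerated than methoxy as far as can be read: an at least 14-fold higher number from compound 1 to compound 3 (1.15 log units; beyond the scatter). In this assay compound 3 gives > 50000 nM, a limit of the assay and not a number. The step between compound 2 and compound 3 cannot be read, because both sit at the same limit: the limit of > 50000 nM in this assay, at which 2 of the 3 values shown sit.

Going by these compounds, whether any group on this aromatic carbon gives the same loss stays open, for example fluorine, an amine or ethoxy. On these data alone, how far compound 2 and compound 3 lie beyond the limit also stays open.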